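Replacing the Amine Partner of Compound 1

The compounds below may be only part of what the source reports. "The series", "measured", "known", "first", "only" and "open" are said of these compounds alone.

Compound 1 `Cn1c(=O)c(S(=O)(=O)c2ccc(F)cc2F)cc2cnc(Nc3ccc4[nH]ncc4c3)nc21` is the weakest of the three measured compounds: in a functional assay on K562 cells (Homo sapiens) for inhibition, read by trypan blue exclusion, with a stated time of 72 h (a higher number here means a weaker inhibitor, a lower number a stronger inhibitor), compound 1 gives 50000 nM. Compound 2 `Cn1c(=O)c(S(=O)(=O)c2ccc(F)cc2)cc2cnc(Nc3ccc4[nH]ncc4c3)nc21` gives 10000 nM in this assay, and compound 3 `Cn1c(=O)c(S(=O)(=O)Nc2ccc(F)cc2F)cc2cnc(Nc3ccc4[nH]ccc4c3)nc21` gives 5000 nM. Among the measured compounds shown here, the only single-point step measured is a 5.0-fold lower number from compound 1 to compound 2 (0.70 log units; beyond the scatter). Compound 4 `Cn1c(=O)c(S(=O)(=O)c2ccc(F)cc2F)cc2cnc(Nc3ccc4c(c3)C(=O)C(=O)N4)nc21` differs from compound 1 in another way: a group of 11 heavy atoms (8 carbon, 1 nitrogen, 2 oxygen; one five-membered non-aromatic ring with 1 hetero atom, one six-membered aromatic ring of carbon only) in place of a group of 9 heavy atoms (7 carbon, 2 nitrogen; one five-membered aromatic ring with 2 hetero atoms, one six-membered aromatic ring of carbon only), on a nitrogen on an aromatic ring. For the measured compounds named here, no measured step touches this group, so the three measurements give no direct guidance; the change from compound 1 to compound 2 concerns a different ring. Lacking such guidance, compound 4 is expected to remain close to compound 1, with no change at the digits printed from compound 1 to compound 4 (within the scatter) estimated as no step beyond the scatter. Compound 4 is therefore estimated at 50000 nM, with a range from 12000 nM to 150000 nM.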

Compound 4, half-maximal inhibitory concentration: 30000 nM
Compound 4: middle estimate off by 1.7-fold (0.22 log units), on the high side, and the stated range covers the measured number.
By their numbers in this assay, from the lowest: compounds 3 and 2 (each within the scatter of the next); then compounds 4 and 1 (each within the scatter of the next).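

In this assay, among the compounds shown here, the only step measured at this position, on a nitrogen on an aromatic ring, is a 1.7-fold lower number from compound 1 to compound 4 (0.22 log units; within the scatter). Compound 4 thus shows that the 1H-indazol-5-yl group can give way to a larger group carrying a non-aromatic five-membered ring and two carbonyls without a change beyond the scatter. Nothing given here explains this result.

On these data alone, whether a carboxylic acid or a morpholine on this ring would move the number remains open. So does whether the same exchange would hold on compound 2.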